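Swapping Phenyl for Furan-2-yl in a Deacetylase Series

A few compounds are considered here, and "the series" means these few. Any claim that something is new, unique, unknown or untested is made for them only; others in the source may bear on it.

Of the compounds shown here, two have been measured in an assay on cells for inhibition of protein deacetylase HDAC6 (Mus musculus), read by fluorescence, with a stated time of 30 min, tested at 100 uM; on this read-out lower numbers stand for less inhibition and higher numbers for more inhibition at the one concentration tested (going by the name of the read-out). Compound 1 `COc1ccc(CN(CCN(C)C)c2ccc(C(=O)Nc3cc(I)ccc3N)cn2)cc1` gives 16% in this assay. Compound 2 `COc1ccc(CN(CCN(C)C)c2ccc(C(=O)Nc3cc(-c4ccccc4)ccc3N)cn2)cc1` gives 14% in this assay; on the numbers shown it sits alongside compound 1, the step of a number 2 percentage points lower from compound 1 to compound 2 (within the scatter) being within the scatter, so the two cannot be told apart. Compound 3 `COc1ccc(CN(CCN(C)C)c2ccc(C(=O)Nc3cc(-c4ccco4)ccc3N)cn2)cc1` has not yet been measured. It differs from compound 2 by furan-2-yl in place of phenyl on an aromatic carbon. For the measured compounds named here, the only step recorded so far, a number 2 percentage points lower from compound 1 to compound 2 (within the scatter), concerns the same place on the shared core and was within the scatter, so it gives no indication that a change there moves the read-out. Compound 3 is therefore expected to show a step of no change at the digits printed from compound 2 to compound 3 (within the scatter) in this assay, no larger than the scatter. Compound 3 is estimated at 14% in this assay, with a range from 4% to 25%.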

Compound 3, a percentage reported as inhibition, at one concentration (the size of the read-out at that concentration, not a potency): 15%
The estimate for compound 3 lay 1 percentage points below the measured number; low and high end bracket the measured number.
By their numbers in this assay, from the lowest: compounds 2, 3 and 1 (each within the scatter of the next).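

Introducing an oxygen-containing ring at this aromatic carbon did not separate compound 3 from the earlier compounds in this assay: furan-2-yl in place of phenyl gave a number 1 percentage points higher from compound 2 to compound 3 (within the scatter), and furan-2-yl in place of iodo gave a number 1 percentage points lower from compound 1 to compound 3 (within the scatter). Iodo, phenyl and furan-2-yl therefore cannot be told apart at this place, even though furan-2-yl brings a five-membered aromatic ring with 1 hetero atom and 1 hydrogen-bond acceptor. Nothing at hand explains this lack of separation.

From the compounds shown here alone, it remains open whether a carboxylic acid or an aminomethyl group on this same carbon would move the read-out beyond the scatter. Also unresolved is whether a change elsewhere on the shared core, such as a longer chain in place of the dimethylaminoethyl chain, would do so.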